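Trifluoromethyl in place of fluoro: compound 4

The source may report more compounds than this note shows. Statements on the series, on what has been measured and on what is new or still open speak of the compounds shown alone.

Of the compounds shown here, three have been measured in a functional assay on T47D cells (Homo sapiens) for inhibition, read by CCK-8 assay, with a stated time of 72 h, tested at 10 uM; on this read-out higher numbers stand for more inhibition of growth at the one concentration tested and lower numbers for less inhibition of growth. Compound 1 `CN(C)C(=O)c1cc2cnc(Nc3ccc(NC(=O)C4(C(=O)Nc5ccc(F)cc5)CC4)cc3)nc2n1C1CCCC1` gives 105%, the highest of the three numbers. Compound 2 `CN(C)C(=O)c1cc2cnc(Nc3ccc(NC(=O)C4(C(=O)Nc5ccccc5F)CC4)cc3)nc2n1C1CCCC1` gives 97.8% and compound 3 `Cc1ccc(NC(=O)C2(C(=O)Nc3ccc(Nc4ncc5cc(C(=O)N(C)C)n(C6CCCC6)c5n4)cc3)CC2)cc1` gives 99.6%; the steps of a number 7.2 percentage points lower from compound 1 to compound 2 (within the scatter) and a number 5.4 percentage points lower from compound 1 to compound 3 (within the scatter) both stay within the scatter, as does a number 1.8 percentage points higher from compound 2 to compound 3 (within the scatter). Compound 1 thus stands highest only nominally; nothing separates the three beyond repeat variation, and all sit near complete inhibition.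

Compound 4 `CN(C)C(=O)c1cc2cnc(Nc3ccc(NC(=O)C4(C(=O)Nc5ccc(C(F)(F)F)cc5)CC4)cc3)nc2n1C1CCCC1` differs from compound 1 in one place: trifluoromethyl in place of fluoro on an aromatic carbon. Within the data shown here, no measured step exchanges fluoro for trifluoromethyl on an aromatic carbon. The nearest comparisons are the exchange of fluoro for methyl on an aromatic carbon, a number 5.4 percentage points lower from compound 1 to compound 3 (within the scatter), and the change of 4-fluorophenyl to 2-fluorophenyl on the amide-type nitrogen, a number 7.2 percentage points lower from compound 1 to compound 2 (within the scatter); neither leaves the scatter. With the measured numbers clustered near full inhibition at the one concentration, a further substituent change of this kind is expected to give no step beyond the scatter, a number 5 percentage points lower from compound 1 to compound 4 (within the scatter). Compound 4 is therefore estimated at 100%, within 88% to 110%.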

Compound 4, percent growth inhibition at one concentration: 94.9%
Beside the measured number, compound 4's estimate is 5.1 percentage points above it; low and high end bracket the measured number.
By their numbers in this assay, from the lowest: compounds 4, 2, 3 and 1 (each within the scatter of the next, the first and the last beyond it).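

In this assay, among these compounds, trifluoromethyl in place of fluoro gives the first step to leave the scatter, with a number 10.1 percentage points lower from compound 1 to compound 4 (beyond the scatter), so a substituent change at this aromatic carbon can register even with the numbers near full inhibition. The step is modest and holds only against compound 1: the exchange of methyl for trifluoromethyl gives a number 4.7 percentage points lower from compound 3 to compound 4 (within the scatter), and 4-(trifluoromethyl)phenyl in place of 2-fluorophenyl gives a number 2.9 percentage points lower from compound 2 to compound 4 (within the scatter). Nothing available accounts for the step.

From the compounds shown here alone, what a carboxylic acid or a dimethylamino group would give at this aromatic carbon remains open. Also open, going by these compounds, is whether the step from fluoro to trifluoromethyl would persist at concentrations other than the single one tested, where the compounds might separate more clearly.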